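Replacing the carbamate oxygen link with an amine-bearing chain

This account rests on a few compounds, and the source may have more. Where it says the series, first, only, none or still open, it means among the compounds named here.

Of the compounds shown here, three sharing one core have been tested in a functional assay on the whole organism for inhibition of sodium-dependent dopamine transporter (Mus musculus); a lower number here means that less compound is needed, a higher number that more compound is needed for the effect. Compound 1 `CCCNC(=O)Nc1cccc2c1CN(C)CC2c1ccccc1` carries a propylamino group on its carbonyl carbon, and in this assay it reaches only a limit of > 120 mg/kg, not a number (the limit of > 120 mg/kg in this assay, at which 1 of the 3 values shown sits). Compound 2 `CCOC(=O)Nc1cccc2c1CN(C)CC2c1ccccc1` has ethoxy there instead and gives 2.5 mg/kg. Within the data shown here, compound 3 `CN1Cc2c(NC(=O)OCc3ccccc3)cccc2C(c2ccccc2)C1`, with benzyloxy on the same carbonyl carbon, gives 25 mg/kg, the highest of the two numbers known; its nearest neighbour is compound 2, and the step of a 10-fold higher number from compound 2 to compound 3 (1.00 log units; beyond the scatter) is a modest rise. The other two steps, an at least 48-fold lower number from compound 1 to compound 2 (1.68 log units; beyond the scatter) and an at least 4.8-fold lower number from compound 1 to compound 3 (0.68 log units; beyond the scatter), both fall.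

Compound 4 `CCNCC(=O)Nc1cccc2c1CN(C)CC2c1ccccc1` differs from compound 3 by (ethylamino)methyl in place of benzyloxy on a carbonyl carbon. Among the measured compounds shown here, no measured step exchanges an oxygen-linked group for a carbon-linked one, so the nearest guide is that the oxygen-linked groups in compound 2 and compound 3 both gave numbers, while the nitrogen-linked group in compound 1 gave only a limit. A modest rise is expected, a 1.6-fold higher number from compound 3 to compound 4 (0.20 log units; within the scatter), with wide uncertainty. Compound 4 is therefore estimated at 40 mg/kg, between 8 mg/kg and 200 mg/kg.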

Compound 4, dose for half-maximal effect: about 60 mg/kg
Compound 4: middle estimate off by 1.5-fold (0.18 log units), on the low side; low and high end bracket the measured number.
By their numbers in this assay, from the lowest: compound 2; then compound 3; then compound 4. At a limit, above all of these: compound 1.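

A carbon-linked chain carrying an amine on this carbonyl carbon still gives a number in this assay, so a measurable effect here does not require an oxygen-linked group. The change still has a cost: there is a 2.4-fold higher number from compound 3 to compound 4 (0.38 log units; beyond the scatter), and a larger 24-fold higher number from compound 2 to compound 4 (1.38 log units; beyond the scatter), which leaves ethoxy with the lowest number of the set. Compound 1 stands at a limit, not a number, so there is only an at least 2.0-fold lower number from compound 1 to compound 4 (0.30 log units; that floor lies within the scatter), and this floor cannot separate the two compounds: the limit of > 120 mg/kg in this assay, at which 1 of the 4 values shown sits.

The compounds shown leave open whether the amine nitrogen or the carbon link sets the number for compound 4; a plain butyl chain on this carbonyl carbon would tell the two apart. Going by these compounds, how a methoxy group would compare with ethoxy also remains open.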